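A few compounds are considered here, and "the series" means these few. Any claim that something is new, unique, unknown or untested is made for them only; others in the source may bear on it.

Among the measured compounds shown here, compound 1, with structure `COc1cc(/C=C/C(=O)/C=C/c2cc(OC)c(OC)c(OC)c2)ccc1OCc1cn(CCCOc2cc(=O)oc3ccccc23)nn1`, stands as the only compound here with a number to show. In a functional assay on PC-3 cells (Homo sapiens) for inhibition, read by sulforhodamine B assay, with a stated time of 48 h, tested at 50 uM (a higher number here means more inhibition of growth at the concentration tested, a lower number less inhibition of growth), compound 1 gives 12%. Two related compounds carry no number at all: compound 2, with structure `COc1cc(/C=C/C(=O)/C=C/c2ccco2)ccc1OCc1cn(CCCCCOc2cc(=O)oc3ccccc23)nn1`, is reported in this assay as "not active" (no number reported), and compound 3, with structure `COc1cccc(/C=C/C(=O)/C=C/c2ccc(OCc3cn(CCCCOc4cc(=O)oc5ccccc45)nn3)c(OC)c2)c1`, likewise as "not active" (no number reported). Compound 4, with structure `COc1ccc(/C=C/C(=O)/C=C/c2ccc(OCc3cn(CCCOc4cc(=O)oc5ccccc45)nn3)c(OC)c2)cc1`, differs from compound 1 in one place: 4-methoxyphenyl in place of 3,4,5-trimethoxyphenyl on a double-bonded chain carbon bound to a double-bonded chain carbon. For the measured compounds named here, no pair of measured compounds here shows how a change of this kind moves the result, so there is nothing to lean on beyond the low reading of compound 1. The step expected in this assay is therefore small, roughly a number 2 percentage points lower from compound 1 to compound 4 (within the scatter), and no more than the usual scatter. Compound 4 is estimated at 10%, between 0% and 25%.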

Compound 4, percent growth inhibition at one concentration: "not active" (no number reported)
Compound 4 has no reported number here; the estimate stays without a comparison.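

In this assay, among the compounds shown here, compound 4 is reported only as "not active", so no step from compound 1 to compound 4 can be read. Whether swapping 3,4,5-trimethoxyphenyl for 4-methoxyphenyl changes growth inhibition stays open, and nothing here speaks to a cause.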